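Swapping methoxy for butyl on the aryl group of compound 1

This account rests on a few compounds, and the source may have more. Where it says the series, first, only, none or still open, it means among the compounds named here.

Three measured compounds share one core and differ only in what sits on one ring nitrogen. Compound 1 `COc1ccc(N2C(=O)NC3(CSC4=C3C(=O)c3ncccc3C4=O)C2=O)cc1` carries a 4-methoxyphenyl there; in a functional assay on CCRF-SB cells (Homo sapiens) for antiproliferative activity, read by MTT assay, with a stated time of 96 h (a lower number here means a stronger inhibitor, a higher number a weaker inhibitor), compound 1 gives 10 nM, the lowest of the three numbers. Compound 2 `O=C1NC(=O)C2(CSC3=C2C(=O)c2ncccc2C3=O)N1`, with hydrogen in that place, gives 150 nM, and compound 3 `O=C1C2=C(C(=O)c3ncccc31)C1(CS2)NC(=O)N(c2ccccc2)C1=O`, with a plain phenyl, gives 30 nM. Removing the whole 4-methoxyphenyl gave a 15-fold higher number from compound 1 to compound 2 (1.18 log units; beyond the scatter); removing only the methoxy gave a 3.0-fold higher number from compound 1 to compound 3 (0.48 log units; beyond the scatter); putting phenyl onto the bare nitrogen gave a 5.0-fold lower number from compound 2 to compound 3 (0.70 log units; beyond the scatter).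

Compound 4 `CCCCc1ccc(N2C(=O)NC3(CSC4=C3C(=O)c3ncccc3C4=O)C2=O)cc1` alters compound 1 in one place: butyl in place of methoxy on an aromatic carbon. Among the measured compounds shown here, no measured step exchanges the methoxy for another group, so the only guide is that losing it altogether gave a 3.0-fold higher number from compound 1 to compound 3 (0.48 log units; beyond the scatter), a modest step. Butyl keeps a group at that position, so the change is expected to be small, a 1.5-fold higher number from compound 1 to compound 4 (0.18 log units; within the scatter), and its direction is uncertain. Compound 4 is expected to give about 15 nM, within a range from 4 nM to 60 nM.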

Compound 4, half-maximal inhibitory concentration: 190 nM
For compound 4 the middle estimate is 13-fold (1.10 log units) below the measured one; measured number outside the range, above it.
By their numbers in this assay, from the lowest: compound 1; then compound 3; then compounds 2 and 4 (each within the scatter of the next).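

Among the compounds shown here, at this position the choice of group counts for far more than the earlier compounds showed. Butyl in place of methoxy gave a 19-fold higher number from compound 1 to compound 4 (1.28 log units; beyond the scatter) and butyl in place of hydrogen on the same aromatic carbon gave a 6.3-fold higher number from compound 3 to compound 4 (0.80 log units; beyond the scatter) so here a butyl does worse than no group at all, and simply keeping a group on that carbon does not preserve the low number. The whole 4-butylphenyl group, set against a bare ring nitrogen, gave a 1.3-fold higher number from compound 2 to compound 4 (0.10 log units; within the scatter) which means the gain seen with phenyl on that nitrogen is not kept once butyl is added. Nothing measured here explains this result.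

Still open, from the compounds shown here alone, is whether the chain length itself sets the size of the loss, which methyl or ethyl on the same carbon could test. Ethoxy, hydroxyl or an amine there could show whether an oxygen or nitrogen attached to the aromatic carbon matters.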